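Methoxymethoxy Enters a Shared Core: Expected Cytotoxicity

The source may hold more compounds than are shown below. What is called first, only, known or untested is meant among the compounds shown, and "the series" means these compounds.

Three compounds share one core and differ only in a single group on one aromatic ring. Compound 1 `O=C(/C=C/c1ccc2c(c1)B(O)OC2)c1ccc(O)cc1` carries a hydroxy group there, compound 2 `O=C(/C=C/c1ccc2c(c1)B(O)OC2)c1ccc(I)cc1` an iodo group, and compound 3 `O=C(/C=C/c1ccc2c(c1)B(O)OC2)c1ccccc1` a hydrogen. All three were tested in an ADME assay on L929 cells (Mus musculus) for cytotoxicity, read by resazurin assay, with a stated time of 72 h; on this read-out lower numbers stand for stronger inhibition and higher numbers for weaker inhibition. In this assay compound 1 gives > 10 ug/mL, which is a limit of the assay rather than a number. Compound 2 gives > 10 ug/mL in this assay, again a limit. Compound 3 gives > 10 ug/mL in this assay, also a limit. Because every value sits at the limit of > 10 ug/mL in this assay, at which 3 of the 3 values shown sit, none of the steps between them can be read: the step that the two limits leave unreadable from compound 1 to compound 2, the step that the two limits leave unreadable from compound 1 to compound 3 and the step that the two limits leave unreadable from compound 2 to compound 3 all have no readable size. Compound 3 thus stands only at a limit, with no measured neighbour placed anywhere else.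

Compound 4 `COCOc1cccc(C(=O)/C=C/c2ccc3c(c2)B(O)OC3)c1` is not yet measured. It differs from compound 3 in one place: methoxymethoxy in place of hydrogen on an aromatic carbon. The three measured steps bear on this change only in that exchanging hydroxy, iodo or hydrogen at this position left every compound at the limit; they give no size in this assay, so no step beyond the scatter can be predicted in either direction. Compound 4 is therefore expected to remain near the limit, at an estimated 15 ug/mL with a likely range from 7 ug/mL to 40 ug/mL. The step that the limit leaves unreadable from compound 3 to compound 4 is expected to be small.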

Compound 4, half-maximal inhibitory concentration: > 10 ug/mL
Compound 4: only a limit was reported; the forecaster's own chance of this, stated with the estimate: 75%; the middle value does not contradict the limit.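

Among the compounds shown here, compound 4 joins compound 3 at a limit in this assay, so no step between these two compounds can be read, and none can be read among the others either: the limit of > 10 ug/mL in this assay, at which 4 of the 4 values shown sit. The compounds shown leave open whether any group at this place on the shared core changes cytotoxicity at all.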